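Amino for nitro on a second dithiole core

The compounds below may be only part of what the source reports. "The series", "measured", "known", "first", "only" and "open" are said of these compounds alone.

Compound 1, with the structure `COc1ccc(-c2c(-c3cc(OC)c(OC)c(OC)c3)ssc2=S)cc1[N+](=O)[O-]`, was tested in a functional assay on SGC-7901 cells (Homo sapiens) for antiproliferative activity, read by MTT assay, with a stated time of 72 h (a higher number here means a weaker inhibitor, a lower number a stronger inhibitor), where compound 1 gives 44700 nM. Compound 2, `COc1ccc(-c2c(-c3cc(OC)c(OC)c(OC)c3)ssc2=S)cc1N`, differs from it in one place: amino in place of nitro on an aromatic carbon. That change brought a 17-fold lower number from compound 1 to compound 2 (1.23 log units; beyond the scatter), and in this assay compound 2 gives 2620 nM.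

Compound 3, `CO/N=c1/ssc(-c2cc(OC)c(OC)c(OC)c2)c1-c1ccc(OC)c([N+](=O)[O-])c1`, carries the same nitro group on a different core, and the difference between the two cores is not broken down here. In this assay compound 3 reaches only the limit of the assay, > 100000 nM, so no number is known for it. Among the three values recorded, (the limit of > 100000 nM in this assay, at which 1 of the 3 values shown sits).

Compound 4, `CO/N=c1/ssc(-c2cc(OC)c(OC)c(OC)c2)c1-c1ccc(OC)c(N)c1`, has not yet been measured. Among the measured compounds shown here, its relation to compound 3 is amino in place of nitro on an aromatic carbon, which is the same change, at the same kind of place, as the one that carried compound 1 to compound 2. Because compound 3 is known only as a limit, the starting point for compound 4 is open, and the step can only be carried over from the measured pair. On that basis, a step of about an at least 6.6-fold lower number from compound 3 to compound 4 (0.82 log units; beyond the scatter) is expected from compound 3 to compound 4, taking the limit as a floor and the earlier step of a 17-fold lower number from compound 1 to compound 2 (1.23 log units; beyond the scatter) as a guide. Compound 4 is therefore estimated at 15000 nM in this assay, with a range from 4000 nM to 100000 nM, and a real chance that it too returns only a limit.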

Compound 4, half-maximal inhibitory concentration: 1960 nM
Compound 4: the middle estimate sits 7.7-fold (0.88 log units) above what was measured, outside the stated range (below it).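

In this assay, amino in place of nitro on an aromatic carbon gave an at least 51-fold lower number from compound 3 to compound 4 (1.70 log units; beyond the scatter), so the direction of the change held on both cores shown. The size of the change did not simply carry over, and the two steps differ by more than the scatter: the same change on two cores in this assay, a 17-fold lower number (1.23 log units; beyond the scatter) from compound 1 to compound 2 and an at least 51-fold lower number (1.70 log units; beyond the scatter) from compound 3 to compound 4, at least 2.9-fold (0.47 log units) apart, beyond the scatter of two such steps Compound 3 gives > 100000 nM, which is a limit of the assay and not a number, so the step on this core has only a lower bound, and two cores show a shared direction, not a rule for the whole series.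

The compounds shown leave open whether the lower number depends on the amino group itself, or whether a hydroxyl, a methylamino or an acetamide group on the same aromatic carbon, ortho to the methoxy group, would behave in the same way. They also leave open whether the change would run in the same direction on a third core, and whether it would hold if that methoxy group gave way to an ethoxy group or the amino group were moved elsewhere on the ring.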